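Three close values and a methoxy to hydroxy step

The source may hold more compounds than are shown below. What is called first, only, known or untested is meant among the compounds shown, and "the series" means these compounds.

compound 1 `COc1ccc(/C=C2\CCC/C(=C\c3cccc(Cl)c3)C2=O)cc1OC` gives 11900 nM
compound 2 `COc1ccc(/C=C2\CCC/C(=C\c3ccc(Cl)cc3)C2=O)cc1OC` gives 11200 nM
compound 3 `COc1cccc(/C=C2\CCC/C(=C\c3ccc(OC)c(OC)c3)C2=O)c1` gives 11600 nM

All three values come from an ADME assay on NHDF cells (Homo sapiens) for cytotoxicity, read by MTT assay, with a stated time of 72 h (a higher number here means a weaker inhibitor, a lower number a stronger inhibitor), and they sit together. Compound 3 lies within the scatter of both compound 1 and compound 2. Moving the chlorine gives a 1.1-fold lower number from compound 1 to compound 2 (0.03 log units; within the scatter) and replacing 4-chlorophenyl with 3-methoxyphenyl gives a 1.0-fold higher number from compound 2 to compound 3 (0.02 log units; within the scatter) as the other measured change.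

Compound 4 `COc1ccc(/C=C2\CCC/C(=C\c3cccc(O)c3)C2=O)cc1OC` differs from compound 3 in one place: hydrogen in place of methyl on an oxygen on an aromatic ring which reads as hydrogen in place of methyl on an oxygen on an aromatic ring, or 3-methoxyphenyl to 3-hydroxyphenyl. Among the compounds with values here, no measured step removes that methyl, so the evidence is indirect. Within the data shown here, the closest precedent is methoxy in place of chloro in a 1.0-fold lower number from compound 1 to compound 3 (0.01 log units; within the scatter) and on that basis no step beyond the scatter is expected in this assay here. The expected step is a 1.1-fold lower number from compound 3 to compound 4 (0.02 log units; within the scatter) with no firm direction. Compound 4 is estimated at 11000 nM with an expected range of 5500 nM to 22000 nM for this measurement.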

Compound 4, half-maximal inhibitory concentration: 6800 nM
The estimate for compound 4 lay 1.6-fold (0.21 log units) above the measured number; low and high end bracket the measured number.
By their numbers in this assay, from the lowest: compounds 4, 2, 3 and 1 (each within the scatter of the next).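

The step to the hydroxy group gives a 1.7-fold lower number from compound 3 to compound 4 (0.23 log units; within the scatter) in this assay, so the series now includes a hydroxy group on this aromatic ring, and the change from methoxy to hydroxy stays within the scatter. The comparisons with the chlorinated compounds read the same way, with a 1.6-fold lower number from compound 2 to compound 4 (0.22 log units; within the scatter) and a 1.8-fold lower number from compound 1 to compound 4 (0.24 log units; within the scatter), so neither the chloro nor the methoxy group separates from hydroxy here. No supporting measurement offers an explanation for these steps.

Going by these compounds, whether any group at this place can produce a step beyond the scatter remains open. An amine, a carboxylic acid or a longer chain on the oxygen, such as ethoxy, would test this, and the compounds shown give no reading for any of them.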